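Aryl substituent swap on the shared core, compound 2 to 3

This account rests on a few compounds, and the source may have more. Where it says the series, first, only, none or still open, it means among the compounds named here.

Among the compounds with values here, compound 2 `COc1cccc(-c2nn(-c3ccccc3)cc2C(Nc2nc3ccc(Cl)cc3s2)c2c(O)ccc3ccccc23)c1` gives 49800 nM in a functional assay on A549 cells (Homo sapiens) for antiproliferative activity, read by MTT assay, with a stated time of 48 h; on this read-out higher numbers stand for weaker inhibition and lower numbers for stronger inhibition; this is the highest of the two numbers so far, with compound 1 `Oc1ccc2ccccc2c1C(Nc1nc2ccc(Cl)cc2s1)c1cn(-c2ccccc2)nc1-c1ccc(F)cc1` nearest at 32200 nM, a gap within the scatter. Compound 3 `Oc1ccc2ccccc2c1C(Nc1nc2ccc(Cl)cc2s1)c1cn(-c2ccccc2)nc1-c1cccc(Cl)c1` differs from compound 2 by chloro in place of methoxy on an aromatic carbon, that is, 3-methoxyphenyl to 3-chlorophenyl. Within the data shown here, the only measured step at this aryl group, a 1.5-fold higher number from compound 1 to compound 2 (0.19 log units; within the scatter), stayed within the scatter, so no step beyond the scatter is expected here either. Compound 3 is therefore estimated at 40000 nM, range 15000 nM to 100000 nM, meaning an expected step of a 1.2-fold lower number from compound 2 to compound 3 (0.10 log units; within the scatter).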

Compound 3, half-maximal inhibitory concentration: 33300 nM
The estimate for compound 3 lay 1.2-fold (0.08 log units) above the measured number; the measured number falls inside the stated range.
By their numbers in this assay, from the lowest: compounds 1, 3 and 2 (each within the scatter of the next).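

At this aryl position, chloro in place of methoxy gives a 1.5-fold lower number from compound 2 to compound 3 (0.17 log units; within the scatter), and 3-chlorophenyl in place of 4-fluorophenyl gives a 1.0-fold higher number from compound 1 to compound 3 (0.01 log units; within the scatter). All three aryl groups therefore read alike within the scatter in this assay, extending the flat picture from a single step to three substituted phenyl groups. No other data bear on this result.

As far as these compounds go, whether an amine or a carboxylic acid on this phenyl ring would produce a step beyond the scatter remains open. The same holds for changes elsewhere on the shared core.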